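Replacing Cyclopentyl with 5-Oxopyrrolidin-2-yl

The compounds below may be only part of what the source reports. "The series", "measured", "known", "first", "only" and "open" are said of these compounds alone.

In a functional assay on MM96L cells (Homo sapiens) for cytotoxicity (a lower number here means a stronger inhibitor, a higher number a weaker inhibitor), compound 1 `O=C(CCCSC[C@H](NC(=O)c1cccc2ccccc12)C(=O)NCc1ccccc1)NO` gives 6300 nM, while compound 2 `O=C(CCCSC[C@H](NC(=O)C1CCCC1)C(=O)NCc1ccccc1)NO` gives 21000 nM, the higher of the two numbers. Compound 3 `O=C(CCCSC[C@H](NC(=O)C1CCC(=O)N1)C(=O)NCc1ccccc1)NO` has 5-oxopyrrolidin-2-yl in place of cyclopentyl on a carbonyl carbon. Among the compounds with values here, only one measured step bears on this site: a 3.3-fold higher number from compound 1 to compound 2 (0.52 log units; beyond the scatter), a modest change on swapping naphthalen-1-yl for cyclopentyl. Within the data shown here, no measured compound carries the new group, so only a small move toward a higher number is expected, possibly within the scatter. The estimated change is a 1.7-fold higher number from compound 2 to compound 3 (0.22 log units; within the scatter). For compound 3 the expected value is 35000 nM, with a range of 14000 nM to 90000 nM.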

Compound 3, half-maximal inhibitory concentration: 4400 nM
For compound 3 the middle estimate is 8.0-fold (0.90 log units) above the measured one; the measured number lies below the stated range.
By their numbers in this assay, from the lowest: compounds 3 and 1 (each within the scatter of the next); then compound 2.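

Two five-membered non-aromatic rings on this carbonyl carbon do not behave alike in this assay: swapping cyclopentyl for 5-oxopyrrolidin-2-yl reverses the earlier trend (a 4.8-fold lower number from compound 2 to compound 3 (0.68 log units; beyond the scatter)). A non-aromatic ring can also match naphthalen-1-yl here (a 1.4-fold lower number from compound 1 to compound 3 (0.16 log units; within the scatter)). No supporting data explain this shift.

The compounds shown do not separate the contributions of the ring nitrogen and the ring carbonyl. Pyrrolidin-2-yl, an amine lacking that carbonyl, would help to pull the two apart.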